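This account rests on a few compounds, and the source may have more. Where it says the series, first, only, none or still open, it means among the compounds named here.

Compound 2 `COc1cccc(C(=O)CC2C(C#N)=C(N)Oc3ccc(Br)cc32)c1` holds the lower of the two numbers in an ADME assay on MCF-10A cells (Homo sapiens) for cytotoxicity, read by sulforhodamine B assay, with a stated time of 72 h, tested at 30 uM (on this read-out higher numbers stand for a stronger effect at the one concentration tested and lower numbers for a weaker effect), where compound 2 gives 43.7%. Within the data shown here, compound 1 `COc1cccc(C(=O)CC2C(C#N)=C(N)Oc3c(OC)cc(Br)cc32)c1` gives 46.3% in this assay, and the single measured step, a number 2.6 percentage points lower from compound 1 to compound 2 (within the scatter), stays inside the scatter, so the two compounds are not separated by this read-out. Compound 3 `Cc1ccc(C(=O)CC2C(C#N)=C(N)Oc3ccc(Br)cc32)cc1` differs from compound 2 at the carbonyl carbon: 4-methylphenyl in place of 3-methoxyphenyl on a carbonyl carbon. Among the measured compounds shown here, no measured step touches this part of the molecule, so the change from compound 1 to compound 2 offers only the general sense that the read-out moves little between close relatives. Compound 3 is therefore expected to give about 44% in this assay, with a range from 30% to 58%. The expected step is a number 0.3 percentage points higher from compound 2 to compound 3 (within the scatter), nothing beyond the scatter.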

Compound 3, a percentage reported as activity, at one concentration (the size of the read-out at that concentration, not a potency): 33.5%
Compound 3: the middle estimate sits 10.5 percentage points above what was measured; the measured number falls inside the stated range.
By their numbers in this assay, from the lowest: compound 3; then compounds 2 and 1 (each within the scatter of the next).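

The aryl group on the carbonyl carbon proved able to move the read-out in this assay: replacing 3-methoxyphenyl with 4-methylphenyl gave a number 10.2 percentage points lower from compound 2 to compound 3 (beyond the scatter), a modest change, whereas the earlier replacement of methoxy with hydrogen on an aromatic carbon gave a number 2.6 percentage points lower from compound 1 to compound 2 (within the scatter). This single step exchanges the oxygen-bearing group for an all-carbon one and also alters the numbered place of the substituent, so the two changes cannot be told apart. Nothing available accounts for the lower number.

On these data alone, it remains open whether 3-methylphenyl or 4-methoxyphenyl would separate the effect of the group from that of its place. As far as these compounds go, the response of this position to an unsubstituted phenyl, an amine or a carboxylic acid also remains unknown.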